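This account rests on a few compounds, and the source may have more. Where it says the series, first, only, none or still open, it means among the compounds named here.

In a physicochemical assay for solubility, with a stated time of 24 h, at pH 2.2 (on this read-out lower numbers stand for lower solubility and higher numbers for higher solubility), compound 1 `CN(C)C(=O)c1c[nH]c2ccccc12` gives > 47 ug/mL as its result, which is a limit and not a number. Compound 2 `Cn1cc(C(=O)N2CCC(C(N)=O)CC2)c2ccccc21` gives > 71 ug/mL as its result, also a limit. Compound 1 therefore has no exact place on the scale. Compound 3 `CN(C)C(=O)c1cn(C)c2ccccc12` differs from compound 1 in one place. The change methyl in place of hydrogen on an aromatic nitrogen puts methyl in place of hydrogen on an aromatic nitrogen. Within the data shown here, no measured pair shows this change, so only a small downward step or none beyond the scatter is expected in this assay for this pair. The estimated step that the limit leaves unreadable from compound 1 to compound 3 is small. Compound 3 is expected at 50 ug/mL with an estimated range of 25 ug/mL to 60 ug/mL.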

Compound 3, solubility: > 51 ug/mL
Compound 3: only a limit was reported (the forecaster's own chance of this, stated with the estimate: 75%); at least 1.0-fold (0.00 log units) between middle value and limit.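

Compound 1 and compound 3 are both reported only as limits, and the step between them cannot be read. Still open, going by these compounds, are their exact values and whether methyl in place of hydrogen on the aromatic nitrogen shifts the result.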